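A few compounds are considered here, and "the series" means these few. Any claim that something is new, unique, unknown or untested is made for them only; others in the source may bear on it.

Of the compounds shown here, two sharing one core have been measured so far. Compound 1 `O=C(CCN1C(=O)CSc2ccccc21)N1CCN(c2ccc([N+](=O)[O-])cc2)CC1` carries a nitro-substituted phenyl ring on the piperazine nitrogen, and in a functional assay on IMR-32 cells (Homo sapiens) for inhibition, read by sulforhodamine B assay, with a stated time of 48 h (a higher number here means a weaker inhibitor of growth, a lower number a stronger inhibitor of growth), compound 1 gives 340 nM. Compound 2 `O=C(CCN1C(=O)CSc2ccccc21)N1CCN(c2ccc(F)cc2)CC1` differs from it in one place, and in this assay compound 2 gives 10000 nM. The step of a 29-fold higher number from compound 1 to compound 2 (1.47 log units; beyond the scatter) is large, so compound 2 stands as the higher, weaker number of the two.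

Compound 3 `COc1ccccc1N1CCN(C(=O)CCN2C(=O)CSc3ccccc32)CC1` has not been measured. The change from compound 2 to compound 3 is 2-methoxyphenyl in place of 4-fluorophenyl on an amine nitrogen in a ring. Among the measured compounds shown here, no measured step covers this exact change; the only step on record, from compound 1 to compound 2, shows that swapping the group on this phenyl ring can move the number by a large amount, in either direction. With so little to go on, the expected step of a 2.5-fold lower number from compound 2 to compound 3 (0.40 log units; beyond the scatter) in this assay is uncertain, with a slight lean back toward a lower number because compound 2 sits at 10000 nM, the weaker end of what has been seen. The expected value for compound 3 in this assay is 4000 nM, with a likely range from 600 nM to 20000 nM.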

Compound 3, concentration for 50% growth inhibition: > 100000 nM
Compound 3 ended at the assay's limit; the forecaster's own chance of this, stated with the estimate: 20%; middle value at least 25-fold (1.39 log units) away from the limit.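

In this assay compound 3 gives > 100000 nM, a limit of the assay and not a number, so the true size of any step to it stays unknown: the limit of > 100000 nM in this assay, at which 1 of the 3 values shown sits.

Even so, swapping 4-fluorophenyl for 2-methoxyphenyl on the amine nitrogen in a ring gives an at least 10-fold higher number from compound 2 to compound 3 (1.00 log units; beyond the scatter), and swapping 4-nitrophenyl for the same group gives an at least 290-fold higher number from compound 1 to compound 3 (2.46 log units; beyond the scatter). Until now, this position had only shown that exchanging one group on the phenyl ring for another could raise the number; these steps show that a third group raises it further still, and that 4-nitrophenyl remains the group with the lowest number, its steps to both others lying beyond the scatter.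

Going by these compounds, what stays open is whether the loss belongs to the methoxy group itself or to where it sits on the phenyl ring, since 2-methoxyphenyl differs from the other two groups in both respects at once, and 4-methoxyphenyl would separate the two. On these data alone, it is also open whether the low number of compound 1 is unique to nitro, or whether a nitrile or a carboxylic acid on the phenyl ring would behave in the same way.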